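Benzylic amide replaced by an ethyl amide on the core

This account rests on a few compounds, and the source may have more. Where it says the series, first, only, none or still open, it means among the compounds named here.

Measured compounds:
compound 1, `CNC(=O)c1cnc(N2CCN(C3CCN(Cc4ccccn4)CC3)[C@@H](C)C2)c(Cl)c1`, 7990 nM
compound 2, `C[C@H]1CN(c2ncc(C(=O)NCc3ccc(F)c(F)c3)cc2Cl)CCN1C1CCN(Cc2ccc(Cl)cc2)CC1`, 6 nM
compound 3, `CNC(=O)c1cnc(N2CCN(C3CCN(Cc4ccc(Cl)cc4)CC3C)CC2)c(Cl)c1`, 64 nM

In a functional assay for antagonist activity at C-X-C chemokine receptor type 3 (Homo sapiens) (on this read-out higher numbers stand for weaker inhibition and lower numbers for stronger inhibition), compound 2 gives the lowest of the three numbers, and its gap to compound 3 as well as to compound 1 lies beyond the scatter. Compound 4, `CCNC(=O)c1cnc(N2CCN(C3CCN(Cc4ccc(Cl)cc4)CC3)[C@@H](C)C2)c(Cl)c1`, has not yet been measured. It differs from compound 2 by methyl in place of 3,4-difluorophenyl on a saturated chain carbon bound to an amide-type nitrogen. Compound 1 and compound 3, which carry the smaller methylcarbamoyl group, both sit at higher numbers than compound 2, so a step upward, beyond the scatter, is expected from compound 2 to compound 4, written as a 10-fold higher number from compound 2 to compound 4 (1.00 log units; beyond the scatter). The value for compound 4 is estimated at 60 nM, in a range from 15 nM to 250 nM.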

Compound 4, half-maximal inhibitory concentration: 2.3 nM
For compound 4 the middle estimate is 26-fold (1.42 log units) above the measured one; the whole stated range lies above it.
By their numbers in this assay, from the lowest: compound 4; then compound 2; then compound 3; then compound 1.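

In this assay, replacing (3,4-difluorobenzyl)carbamoyl with ethylcarbamoyl gives a 2.6-fold lower number from compound 2 to compound 4 (0.42 log units; beyond the scatter), so on this background the 3,4-difluorophenyl ring is not required for a low number. The earlier compounds shown here could not show this, since no two of them differed in only one place. Nothing measured here accounts for the modest gain. Still open, going by these compounds, is how far this tolerance extends, whether to a propyl or longer chain on the amide nitrogen or to the unsubstituted carboxamide. The compounds shown also leave unsettled how methylcarbamoyl compares with ethylcarbamoyl on this same background.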